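The source may hold more compounds than are shown below. What is called first, only, known or untested is meant among the compounds shown, and "the series" means these compounds.

Of the compounds shown here, three sharing one core have been measured in an assay on a cell-free system (plasma) for inhibition of Dipeptidyl peptidase 4 (Rattus norvegicus), read by fluorescence; a higher number here means a weaker inhibitor, a lower number a stronger inhibitor: compound 1 `O=C([C@@H]1C[C@H](N2CCCN(c3ccc([N+](=O)[O-])cc3)CC2)CN1)N1CCSC1` gives 2.9 nM, compound 2 `O=C([C@@H]1C[C@H](N2CCN(c3ccccn3)CC2)CN1)N1CCSC1` gives 3.5 nM, and compound 3 `O=C([C@@H]1C[C@H](N2CCC(c3ccccc3)CC2)CN1)N1CCSC1` gives 9.6 nM. Compound 2 thus stands second highest of the three numbers; its value and that of compound 1 sit within the scatter of each other, while compound 3 gives a higher number that lies beyond it. Compound 4 `O=C([C@@H]1C[C@H](N2CCN(c3ccc(Cl)cn3)CC2)CN1)N1CCSC1` is not yet measured. It differs from compound 2 by chloro in place of hydrogen on an aromatic carbon, two atoms from the ring nitrogen and para to a large group. Going by the values given here, no measured pair shows such a change, so in this assay the step is expected to be none beyond the scatter or at most a slight lowering, a 1.4-fold lower number from compound 2 to compound 4 (0.15 log units; within the scatter). Compound 4 is accordingly estimated at 2.5 nM, within 1 nM to 8 nM.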

Compound 4, half-maximal inhibitory concentration: 3.1 nM
For compound 4 the middle estimate is 1.2-fold (0.09 log units) below the measured one; the measured number falls inside the stated range.
By their numbers in this assay, from the lowest: compounds 1, 4 and 2 (each within the scatter of the next); then compound 3.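

Chloro in place of hydrogen gives a 1.1-fold lower number from compound 2 to compound 4 (0.05 log units; within the scatter) in this assay and so provides the first one-place comparison in the set. At this carbon, two atoms from the ring nitrogen and para to a large group, chloro is accepted with no change beyond the scatter. Nothing at hand explains this result.

On these data alone, whether an amine, a methoxy or a carboxylic acid on the same carbon would also leave the number unmoved stays open. So does the effect of chloro on the ring's other carbons.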